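Chloro to methoxy on a chalcone-furoxan anti-inflammatory hybrid

The compounds below may be only part of what the source reports. "The series", "measured", "known", "first", "only" and "open" are said of these compounds alone.

Measured compounds:
- compound 1, `COc1ccc(/C=C/C(=O)c2ccc(NC(=O)C(C)O[N+](=O)[O-])cc2)cc1`, 50%
- compound 2, `O=C(COCc1c(-c2ccccc2)no[n+]1[O-])Nc1ccc(C(=O)/C=C/c2ccc(Cl)cc2)cc1`, 66%

Two compounds share a chalcone anilide core and were tested in a functional assay on the whole organism (strain albino) for inhibition, with Rattus norvegicus as the target, read by paw edema, with stated times of 30 min and 3 h, at a dose of 100 mg/kg by the oral route; on this read-out lower numbers stand for less inhibition and higher numbers for more inhibition at the one dose given (going by the name of the read-out). Compound 1 gives 50%, while compound 2 gives 66%, the higher of the two numbers, the gap between them lying beyond the usual scatter. The two differ in more than one place, so no single change can be read from them.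

Compound 3, `COc1ccc(/C=C/C(=O)c2ccc(NC(=O)COCc3c(-c4ccccc4)no[n+]3[O-])cc2)cc1`, keeps the furoxan-bearing side chain of compound 2 and alters only the styryl ring: methoxy in place of chloro on an aromatic carbon. Going by the values given here, no measured pair isolates this change. Compound 1, which also carries methoxy at that site but with a different side chain, gave the lower value 50%, which suggests at most a mild loss. Compound 3 is therefore estimated at 58%, between 45% and 70%. The expected step of a number 8 percentage points lower from compound 2 to compound 3 (within the scatter) is a small decrease, not clearly beyond the scatter.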

Compound 3, a percentage reported as inhibition, in the whole organism at one dose (the size of the read-out at that dose, not a potency): 56%
The estimate for compound 3 lay 2 percentage points above the measured number, and the stated range covers the measured number.
By their numbers in this assay, from the lowest: compounds 1, 3 and 2 (each within the scatter of the next, the first and the last beyond it).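

With the side chain of compound 2 held fixed, this assay gives a number 10 percentage points lower from compound 2 to compound 3 (within the scatter) for methoxy in place of chloro on the aromatic carbon para to a large group. This is the first pair shown that isolates this position, and on this read-out, at the one dose given, 4-chlorophenyl and 4-methoxyphenyl cannot be told apart. No measurement shown bears on the reason for this result.

On these data alone, it remains open whether another group at this position, such as an amine, a carboxylic acid or a plain hydrogen, would shift the number beyond the usual scatter. As far as these compounds go, it is also open whether the same exchange of chloro and methoxy would read alike with the shorter nitrate-bearing side chain of compound 1.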